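The source may report more compounds than this note shows. Statements on the series, on what has been measured and on what is new or still open speak of the compounds shown alone.

Measured in a functional assay on MIA PaCa-2 cells (Homo sapiens) for antiproliferative activity; a lower number here means that less compound is needed, a higher number that more compound is needed for the effect:
- compound 1 `Cc1cc2c(C(=O)NCC#N)cccc2n1-c1nc2c(c(NCc3ccccc3)n1)CCCC2`: 468 nM
- compound 2 `C#CCCNC(=O)c1cccc2c1cc(C)n2-c1nc2c(c(NCc3ccccc3)n1)CCCC2`: 1410 nM
- compound 3 `C#CC(=O)Nc1cccc2c1cc(C)n2-c1nc2c(c(NCc3ccccc3)n1)CCCC2`: 131 nM

Compound 3 has the lowest number of the three, and its gaps to both others lie beyond the scatter. Compound 4 `CCC(=O)Nc1cccc2c1cc(C)n2-c1nc2c(c(NCc3ccccc3)n1)CCCC2` carries ethyl in place of ethynyl on a carbonyl carbon. Among the measured compounds shown here, no measured step makes this exact change. The closest evidence is the pair of steps that reach the (ethynylcarbonyl)amino group: the modest 3.6-fold lower number from compound 1 to compound 3 (0.55 log units; beyond the scatter) and the large 11-fold lower number from compound 2 to compound 3 (1.03 log units; beyond the scatter). The modest 3.0-fold higher number from compound 1 to compound 2 (0.48 log units; beyond the scatter) also shows that a change at a chain end can move this assay beyond the scatter. A modest rise is therefore expected, with a 3.8-fold higher number from compound 3 to compound 4 (0.58 log units; beyond the scatter) as the estimated step. For compound 4 the estimate is 500 nM, with an expected range of 170 nM to 1500 nM.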

Compound 4, half-maximal effective concentration: 1010 nM
Compound 4: the middle estimate sits 2.0-fold (0.31 log units) below what was measured, within the range that was stated.
By their numbers in this assay, from the lowest: compound 3; then compound 1; then compounds 4 and 2 (each within the scatter of the next).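

At this carbonyl carbon, ethyl in place of ethynyl gives a 7.7-fold higher number from compound 3 to compound 4 (0.89 log units; beyond the scatter) with the amide-type nitrogen kept, so the low number of compound 3 depends on the ethynyl end and not on the reversed amide alone. Against the carbamoyl compounds, a 2.2-fold higher number from compound 1 to compound 4 (0.33 log units; beyond the scatter) and a 1.4-fold lower number from compound 2 to compound 4 (0.14 log units; within the scatter) leave propanoylamino with none of the lead held by (ethynylcarbonyl)amino. Nothing available explains this step.

From the compounds shown here alone, whether a propenoyl group, with a double bond on the same carbonyl carbon, or a longer chain ending in ethynyl would keep the low number stays open.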